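From cyclopropylamino to piperazin-1-yl on a carbonyl carbon

The compounds below may be only part of what the source reports. "The series", "measured", "known", "first", "only" and "open" are said of these compounds alone.

Measured so far in a functional assay on PC-3 cells (Homo sapiens) for inhibition, read by sulforhodamine B assay, with a stated time of 72 h (on this read-out higher numbers stand for weaker inhibition and lower numbers for stronger inhibition), are these compounds:
compound 1 `Nc1sc(-c2ccc(Cl)cc2)c(-c2ccc(Cl)cc2)c1C(=O)N1CCCC1` gives 6220 nM
compound 2 `COc1ccc(CNC(=O)c2c(N)sc(-c3ccc(Cl)cc3)c2-c2ccc(Cl)cc2)cc1` gives 29500 nM
compound 3 `Nc1sc(-c2ccc(Cl)cc2)c(-c2ccc(Cl)cc2)c1C(=O)NC1CC1` gives 3680 nM

Compound 3 stands at the lower of two levels among these numbers. The gap to its nearest neighbour is a 1.7-fold lower number from compound 1 to compound 3 (0.23 log units; within the scatter) and the gap to its furthest is an 8.0-fold lower number from compound 2 to compound 3 (0.90 log units; beyond the scatter) on the same read-out.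

Compound 4 `Nc1sc(-c2ccc(Cl)cc2)c(-c2ccc(Cl)cc2)c1C(=O)N1CCNCC1` carries piperazin-1-yl in place of cyclopropylamino on a carbonyl carbon.

Within the data shown here, no measured compound carries piperazin-1-yl, so the evidence is indirect. The nearest guide is the exchange between pyrrolidin-1-yl and cyclopropylamino at this same place, which gave a 1.7-fold lower number from compound 1 to compound 3 (0.23 log units; within the scatter) and so stayed small. The exchange of pyrrolidin-1-yl for (4-methoxybenzyl)amino went further, with a 4.7-fold higher number from compound 1 to compound 2 (0.68 log units; beyond the scatter) as a modest rise. Changes here have thus ranged from none beyond the scatter to a modest rise, and neither measured step went beyond the scatter towards a lower number.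

In this assay a small rise is therefore expected, resting mainly on compound 1 at 6220 nM as the closest neighbour. The estimated step is a 1.9-fold higher number from compound 3 to compound 4 (0.28 log units; within the scatter) and no larger shift is firmly expected. The estimate for compound 4 is 7000 nM within an expected range from 2000 nM to 22000 nM for its measured value.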

Compound 4, half-maximal inhibitory concentration: 2710 nM
For compound 4 the middle estimate is 2.6-fold (0.41 log units) above the measured one, and the stated range covers the measured number.
By their numbers in this assay, from the lowest: compounds 4, 3 and 1 (each within the scatter of the next, the first and the last beyond it); then compound 2.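

In this assay, the exchange of cyclopropylamino for piperazin-1-yl on the carbonyl carbon gives a 1.4-fold lower number from compound 3 to compound 4 (0.13 log units; within the scatter), so the larger ring with its second nitrogen leaves the number level with that of compound 3. Unlike cyclopropylamino, piperazin-1-yl separates from pyrrolidin-1-yl, with a 2.3-fold lower number from compound 1 to compound 4 (0.36 log units; beyond the scatter), and the exchange for (4-methoxybenzyl)amino gives an 11-fold lower number from compound 2 to compound 4 (1.04 log units; beyond the scatter), the largest step among these four compounds. Compound 4 also lacks the amide hydrogen that compound 3 carries, so among these compounds a low number at this place does not depend on that hydrogen, although nothing available here accounts for any of these steps.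

The compounds shown leave open how piperidin-1-yl or morpholin-4-yl would read, with a carbon or an oxygen in place of the second ring nitrogen, and so whether that nitrogen itself matters. They also leave open whether a methyl or an acetyl group on that nitrogen would keep the number at the level of compound 4.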